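Losing the chloro group from compound 3

The compounds below may be only part of what the source reports. "The series", "measured", "known", "first", "only" and "open" are said of these compounds alone.

Three compounds that share one core were tested in an ADME assay (liver) for metabolic stability, with Liver microsome (Rattus norvegicus) as the target, read by LC-MS, using microsomes and NADPH, with stated times of 5 min and 60 min, tested at 4 uM; a higher number here means that more of the compound is left, a lower number that less of the compound is left. Compound 1 `Cc1c(OCCCCOCOc2ccc(C(=O)O)cc2)ccc(C(=O)CC2CCCC2)c1O` gives 31%, compound 2 `Cc1c(OCCCCOc2ccc(C(=O)O)cc2F)ccc(C(=O)CC2CCCC2)c1O` gives 66% and compound 3 `Cc1c(OCCCCOc2ccc(C(=O)O)cc2Cl)ccc(C(=O)CC2CCCC2)c1O` gives 21%. Compound 3 therefore sits at the low end of this small set, and its nearest neighbour shows a number 10 percentage points lower from compound 1 to compound 3 (within the scatter).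

Compound 4 `Cc1c(OCCCCOc2cccc(C(=O)O)c2)ccc(C(=O)CC2CCCC2)c1O` has not yet been measured. It differs from compound 3 as follows: 3-carboxyphenyl in place of 4-carboxy-2-chlorophenyl on an oxygen on a saturated carbon. In words, 3-carboxyphenyl stands in place of 4-carboxy-2-chlorophenyl on an oxygen on a saturated carbon.

Among the measured compounds shown here, the closest guide is the only measured step that alters the chloro group alone, a number 45 percentage points lower from compound 2 to compound 3 (beyond the scatter). Another large step, a number 35 percentage points higher from compound 1 to compound 2 (beyond the scatter), shows that changes in this end group can matter in this assay. For the measured compounds named here, neither step is a direct precedent, since no measured compound carries the 3-carboxyphenyl group. A rise of moderate size is therefore expected, smaller than the large steps, with real uncertainty in both directions. The estimate amounts to a number 19 percentage points higher from compound 3 to compound 4 (beyond the scatter), a step that is expected but not certain. For compound 4 the estimated value is 40%, with an expected range from 15% to 70%.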

Compound 4, percent of the compound remaining: 55%
Beside the measured number, compound 4's estimate is 15 percentage points below it; measured number inside the range.
By their numbers in this assay, from the lowest: compounds 3 and 1 (each within the scatter of the next); then compound 4; then compound 2.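

The 3-carboxyphenyl group carries no halogen, and putting it in place of the chlorinated ring gives a number 34 percentage points higher from compound 3 to compound 4 (beyond the scatter) in this assay. A ring with neither chlorine nor fluorine can therefore leave far more compound behind than the chlorinated ring does, and the same group also gives a number 24 percentage points higher from compound 1 to compound 4 (beyond the scatter). It still falls short of the fluorinated ring, with a number 11 percentage points lower from compound 2 to compound 4 (beyond the scatter), so among these compounds the halogen-free ring lies between the two halogen-bearing rings, and having a halogen at this end does not by itself push the number one way.

Nothing shown explains why these numbers differ. From the compounds shown here alone, this change also removes the chloro group and alters the numbered place of the carboxylic acid at once, so their separate shares stay open, and a 4-carboxyphenyl group with no halogen, a 3-carboxyphenyl group bearing a fluoro group, or a primary amide in place of the carboxylic acid would each address a question these compounds cannot answer.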